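Swapping a thiazole substituent while the methylphenyl ether stays

The source may hold more compounds than are shown below. What is called first, only, known or untested is meant among the compounds shown, and "the series" means these compounds.

Measured compounds:
compound 1 `Cc1ccccc1OCc1ccccc1-c1nc(COc2ccc(Cl)cc2)cs1` gives 65.1%
compound 2 `Cc1ccc(OCc2ccccc2-c2nc(COc3ccc(Cl)cc3)cs2)cc1` gives 68.7%
compound 3 `Cc1cccc(OCc2ccccc2-c2nc(-c3cc(Cl)sc3S(N)(=O)=O)cs2)c1` gives 66.8%

All three were tested in a functional assay on the whole organism (strain Wistar albino) for inhibition, with Rattus norvegicus as the target, read by paw edema, at a dose of 10 mg/kg by the oral route; a higher number here means more inhibition at the dose given (going by the name of the read-out), a lower number less inhibition. Compound 3 stands second highest of the three numbers; its nearest neighbour is compound 1, lower by a margin within the scatter, and compound 2 lies above it, again within the scatter. Compound 4 `Cc1cccc(OCc2ccccc2-c2nc(COc3ccc(Cl)cc3)cs2)c1` has not been measured. Its change from compound 3 is (4-chlorophenoxy)methyl in place of 5-chloro-2-sulfamoylthiophen-3-yl on an aromatic carbon. Going by the values given here, no measured step matches this change directly. Among the compounds with values here, the one step recorded, a number 3.6 percentage points higher from compound 1 to compound 2 (within the scatter), moves the methyl on the phenyl ether and stays within the scatter, so it bears on the change only indirectly. Compounds 1 and 2 already carry the (4-chlorophenoxy)methyl group that enters in compound 4, and their values sit close to that of compound 3. The expected step of a number 0.2 percentage points higher from compound 3 to compound 4 (within the scatter) is therefore none beyond the scatter. Compound 4 is estimated at 67%, with a range from 58% to 76%.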

Compound 4, a percentage reported as inhibition, in the whole organism at one dose (the size of the read-out at that dose, not a potency): 67.7%
Compound 4: middle estimate off by 0.7 percentage points, on the low side; the measured number falls inside the stated range.
By their numbers in this assay, from the lowest: compounds 1, 3, 4 and 2 (each within the scatter of the next).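

In this assay, putting (4-chlorophenoxy)methyl in place of 5-chloro-2-sulfamoylthiophen-3-yl, on the aromatic carbon next to the ring nitrogen, gives a number 0.9 percentage points higher from compound 3 to compound 4 (within the scatter), so two very different groups cannot be told apart here at this dose. The new compound also completes the set of methyl placements on the phenyl ether. With (4-chlorophenoxy)methyl held in place, 3-methylphenyl in place of 4-methylphenyl gives a number 1 percentage points lower from compound 2 to compound 4 (within the scatter), and 3-methylphenyl in place of 2-methylphenyl gives a number 2.6 percentage points higher from compound 1 to compound 4 (within the scatter), so this change makes no readable difference either.

Nothing available accounts for these closely matching numbers. From the compounds shown here alone, it remains open whether an amine or a carboxylic acid at the thiazole-bearing position, or a longer chain in place of the methyl, would shift the read-out beyond the scatter.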